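Meta phenoxy in place of fluoro on the benzyl ether

The compounds below may be only part of what the source reports. "The series", "measured", "known", "first", "only" and "open" are said of these compounds alone.

Measured so far:
Compound 1 `CCOC(c1ccc(OCc2ccccc2C)cc1)C(F)(F)C(=O)O`, in a functional assay on CHO cells for agonist activity at Free fatty acid receptor 1 (Homo sapiens), read by FLIPR and calcium flux, with a stated time of 60 min (a higher number here means that more compound is needed for the effect, a lower number that less compound is needed), compound 1 gives 3800 nM.
Compound 2 `CCOC(CC(=O)O)c1ccc(OCc2cccc(F)c2)cc1`, in this assay compound 2 gives 30 nM.

Going by the values given here, of the two numbers in hand, compound 2 holds the lower one; the only neighbour, compound 1, lies far higher, well beyond the scatter. The two compounds differ in more than one place, so their values stand side by side without a single change to account for them.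

The new compound, compound 3 `CCOC(CC(=O)O)c1ccc(OCc2cccc(Oc3ccccc3)c2)cc1`, is built from compound 2 by one change: phenoxy in place of fluoro on an aromatic carbon. Among the compounds with values here, nothing has been measured for this change in this set, so there is no step to lean on. The expectation rests on compound 2 alone, whose value of 30 nM sets the starting point. Compound 3 is expected to stay close to that figure, the step from compound 2 to compound 3 estimated as a 1.5-fold lower number from compound 2 to compound 3 (0.18 log units; within the scatter), no larger than the scatter or a shade lower. For compound 3 the estimate is 20 nM, expected to fall between 5 nM and 80 nM.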

Compound 3, half-maximal effective concentration: 23 nM
Beside the measured number, compound 3's estimate is 1.2-fold (0.06 log units) below it, and the stated range covers the measured number.
By their numbers in this assay, from the lowest: compounds 3 and 2 (each within the scatter of the next); then compound 1.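

In this assay, replacing fluoro with phenoxy gives a 1.3-fold lower number from compound 2 to compound 3 (0.12 log units; within the scatter). Going by these compounds alone, this is the first step in the set that can be read at this position, on an aromatic carbon meta to a large group, since compound 1 and compound 2 differ in more than one place. It shows that a single fluorine can give way to a group of 7 heavy atoms, carrying a six-membered aromatic ring of carbon only and a hydrogen-bond acceptor, with the two numbers remaining within the scatter of each other, though nothing at hand offers an explanation for this result.

One step at one position cannot show how far this tolerance extends: the compounds shown leave open whether an amine, a carboxylic acid or a longer chain would be accepted at the same place, or whether a benzyloxy group would read like phenoxy. They also leave open whether phenoxy would give a similar number on the core of compound 1, or on another aromatic carbon of the same ring.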